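Amino in Place of Chloro on the Shared Core

A few compounds are considered here, and "the series" means these few. Any claim that something is new, unique, unknown or untested is made for them only; others in the source may bear on it.

Compound 1 `OCC(CO)OCn1c(Cl)nc2cc(Cl)c(Cl)cc21` was tested in a functional assay on KB cells (Homo sapiens) for inhibition; a higher number here means a weaker inhibitor, a lower number a stronger inhibitor. In this assay compound 1 gives only a limit of the assay, > 100000 nM. Compound 2 `OCC(CO)OCn1c(Cl)nc2c(Cl)c(Cl)ccc21` also gives in this assay only a limit, > 100000 nM. That is the limit of > 100000 nM in this assay, at which 2 of the 2 values shown sit, so compound 1 stands at the weak end of what has been measured, without a number of its own. Compound 3 `Nc1nc2cc(Cl)c(Cl)cc2n1COC(CO)CO` has not been measured; it differs from compound 1 by amino in place of chloro on an aromatic carbon. For the measured compounds named here, with no measured step to lean on, the expected change from compound 1 to compound 3 is an at least 1.2-fold lower number from compound 1 to compound 3 (0.09 log units; that floor lies within the scatter), likely small. For compound 3 the estimate is 80000 nM, within 10000 nM to 300000 nM.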

Compound 3, half-maximal inhibitory concentration: > 100000 nM
Compound 3 was reported as a limit; the forecaster's own chance of this, stated with the estimate: 65%; at least 1.2-fold (0.09 log units) between middle value and limit.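

No step can be read from compound 1 to compound 3, since both stop at the same reported limit: the limit of > 100000 nM in this assay, at which 3 of the 3 values shown sit. As far as these compounds go, whether amino in place of chloro changes inhibition at all stays open.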